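From Phenyl to 1-Benzofuran-2-yl at the Assay Limit

The source may report more compounds than this note shows. Statements on the series, on what has been measured and on what is new or still open speak of the compounds shown alone.

So far, two compounds have been tested in a functional assay on HCT-116 cells (Homo sapiens), read by MTT assay, with a stated time of 72 h (on this read-out lower numbers stand for stronger inhibition and higher numbers for weaker inhibition), and neither gives an exact number. Compound 1 `CN(C)c1ncnc2c1c(-c1ccsc1)cn2[C@@H]1O[C@H](CO)[C@@H](O)[C@H]1O` reads > 20000 nM here, which is a limit of the assay. Compound 2 `O=c1[nH]cnc2c1c(-c1ccccc1)cn2[C@@H]1O[C@H](CO)[C@@H](O)[C@H]1O` reads > 100000 nM as a limit too, so it offers no exact starting value.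

Compound 3 `O=c1[nH]cnc2c1c(-c1cc3ccccc3o1)cn2[C@@H]1O[C@H](CO)[C@@H](O)[C@H]1O`, still unmeasured, carries 1-benzofuran-2-yl in place of phenyl on an aromatic carbon. For the measured compounds named here, no measured step shows what such an exchange does, so any expectation is loose. A modest move towards stronger inhibition in this assay is expected, and another limit is quite possible. The estimate means an at least 1.6-fold lower number from compound 2 to compound 3 (0.22 log units; that floor lies within the scatter) as the expected step. For compound 3 the expected value is 60000 nM with an estimated range from 15000 nM to 150000 nM overall.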

Compound 3, half-maximal inhibitory concentration: > 20000 nM
Compound 3 gave a limit, no number; the forecaster's own chance of this, stated with the estimate: 65%; the middle value does not contradict the limit.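

For the compounds shown here, compound 2 and compound 3 both gave limits rather than exact numbers, so no step between them can be read. The compounds shown leave open whether 1-benzofuran-2-yl in place of phenyl strengthens or weakens inhibition, and by how much.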